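The source may report more compounds than this note shows. Statements on the series, on what has been measured and on what is new or still open speak of the compounds shown alone.

Measured in an ADME assay on BJ cells (Homo sapiens) for cytotoxicity, read by luminescence, with a stated time of 72 h; a lower number here means that less compound is needed, a higher number that more compound is needed for the effect:
- compound 1 `CCOC(=O)c1c(-c2cccc(C)c2)[nH]c2cc(OC)ccc2c1=O`: > 21500 nM
- compound 2 `CCOC(=O)c1c(-c2cccc(OCC)c2)[nH]c2cc(OC)ccc2c1=O`: > 21500 nM
- compound 3 `CCOC(=O)c1c(-c2cccc(Cl)c2)[nH]c2cc(OC)ccc2c1=O`: > 21500 nM

Each of these three entries is a limit of the assay and not a number. Compound 3 stands at > 21500 nM, which is a limit, so it has no exact place among the three compounds. The evidence on them is simple: the limit of > 21500 nM in this assay, at which 3 of the 3 values shown sit.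

The next compound is compound 4 `CCOC(=O)c1c(-c2cccc(C(C)=O)c2)[nH]c2cc(OC)ccc2c1=O`. It has acetyl in place of chloro on an aromatic carbon, at the position meta to a large group: acetyl in place of chloro on an aromatic carbon.

Among the measured compounds shown here, three measured steps bear on this change: a step that the two limits leave unreadable from compound 1 to compound 2, a step that the two limits leave unreadable from compound 1 to compound 3 and a step that the two limits leave unreadable from compound 2 to compound 3. None of them has a readable size, so they show no effect of the group at this position in either direction. The swaps among methyl, ethoxy and chloro all end at the same limit, and on that basis no step beyond the scatter is expected in this assay. Compound 4 is expected to report only a limit as well.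

The expected step, which is an estimate only, is a step that the limit leaves unreadable from compound 3 to compound 4. For compound 4 the estimated value is 30000 nM. The expected range for compound 4 runs from 15000 nM to 60000 nM.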

Compound 4, half-maximal effective concentration: > 21500 nM
Compound 4: a limit, no number; the forecaster's own chance of this, stated with the estimate: 85%; the middle value lies beyond the limit too.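

Compound 4 gives > 21500 nM in this assay, which is a limit and not a number, so no new step can be read between compound 4 and compound 1, compound 2 or compound 3. The compounds shown leave open how the four would compare in this assay if each had an exact value, and whether any group at this position gives a readable value.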